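A few compounds are considered here, and "the series" means these few. Any claim that something is new, unique, unknown or untested is made for them only; others in the source may bear on it.

In a functional assay on HepG2 cells (Homo sapiens) for inhibition, read by MTT assay, with a stated time of 3 days (on this read-out lower numbers stand for stronger inhibition and higher numbers for weaker inhibition), compound 1 `CC[C@H](C)[C@@H](NCC(=O)NNC(=O)COc1ccc(-c2nc3ccccc3s2)cc1OC)C(=O)O` gives 3990 nM and compound 2 `COc1cc(-c2nc3ccccc3s2)ccc1OCC(=O)NNC(=O)CN(C(C)=O)[C@@H](CS)C(=O)O` gives 3420 nM as its reading, so the two stand level within the usual scatter. Compound 3 `COc1cc(-c2nc3ccccc3s2)ccc1OCC(=O)NNC(=O)CN[C@@H](CS(=O)(=O)O)C(=O)O` keeps the shared core of compound 2 and differs on a saturated chain carbon bound to a carbonyl carbon, where (1-carboxy-2-sulfoethyl)amino takes the place of acetyl(1-carboxy-2-sulfanylethyl)amino ((1-carboxy-2-sulfoethyl)amino in place of acetyl(1-carboxy-2-sulfanylethyl)amino on a saturated chain carbon bound to a carbonyl carbon). Going by the values given here, only one measured step touches this place: a 1.2-fold lower number from compound 1 to compound 2 (0.07 log units; within the scatter) and it stayed within the scatter. Among the compounds with values here, no shift beyond the scatter is therefore expected in this assay, although a single step is thin evidence and no measured compound carries the sulfo group. The estimated change is a 1.1-fold higher number from compound 2 to compound 3 (0.05 log units; within the scatter) and so remains small. Compound 3 is expected to give about 3800 nM with 1400 nM to 10000 nM as its estimated range.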

Compound 3, half-maximal inhibitory concentration: 3690 nM
Beside the measured number, compound 3's estimate is 1.0-fold (0.01 log units) above it; measured number inside the range.
By their numbers in this assay, from the lowest: compounds 2, 3 and 1 (each within the scatter of the next).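

In this assay, (1-carboxy-2-sulfoethyl)amino in place of acetyl(1-carboxy-2-sulfanylethyl)amino gives a 1.1-fold higher number from compound 2 to compound 3 (0.03 log units; within the scatter), so the sulfo group, new to this series, brings no change that can be told from the scatter. Read on the amine nitrogen, 1-carboxy-2-sulfoethyl in place of 1-carboxy-2-methylbutyl gives a 1.1-fold lower number from compound 1 to compound 3 (0.03 log units; within the scatter), also within the scatter, so all three side chains shown at this place stand level in this cell assay. Nothing available explains why these different groups read alike.

As far as these compounds go, all three groups carry a carboxylic acid, so it remains open whether a methyl ester or a primary amide in its place would read differently. A simple amine without the carboxylic acid is likewise untested among the compounds shown.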